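Taking one hydroxy off compound 2

A few compounds are considered here, and "the series" means these few. Any claim that something is new, unique, unknown or untested is made for them only; others in the source may bear on it.

In a functional assay on 786-0 cells (Homo sapiens) for inhibition, read by sulforhodamine B assay, with a stated time of 48 h (a lower number here means a stronger inhibitor of growth, a higher number a weaker inhibitor of growth), compound 1 `CCOC(=O)C1=C(C)NC(=S)NC1c1ccc(F)cc1` reads 24.5 ug/mL and serves as the reference for the series. Compound 2 `CCOC(=O)C1=C(C)NC(=O)NC1c1ccc(O)c(O)c1` reads 25.7 ug/mL in the same test, which lies within the scatter of compound 1, so the two stand level. Compound 3 `CCOC(=O)C1=C(C)NC(=O)NC1C1CCCCC1` returns > 250 ug/mL in this assay as a limit of the assay and not as a number.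

Compound 4 `CCOC(=O)C1=C(C)NC(=O)NC1c1ccc(O)cc1` has not yet been measured. It differs from compound 2 at one place (hydrogen in place of hydroxy on an aromatic carbon): hydrogen in place of hydroxy on an aromatic carbon, ortho to a hydroxy group and meta to a large group.

Among the compounds with values here, no measured pair shows this change alone, so the expectation rests on indirect ground. Compound 1 at 24.5 ug/mL carries no hydroxy on its aromatic ring and still stands level with compound 2, although it also differs elsewhere. The step expected is a 1.2-fold higher number from compound 2 to compound 4 (0.10 log units; within the scatter) and it is estimated to stay within the scatter, leaning slightly towards a higher number. In this assay the estimate for compound 4 is 32 ug/mL (expected range 12 ug/mL to 90 ug/mL).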

Compound 4, concentration for 50% growth inhibition: 25.8 ug/mL
Compound 4: the middle estimate sits 1.2-fold (0.09 log units) above what was measured; the measured number falls inside the stated range.
By their numbers in this assay, from the lowest: compounds 1, 2 and 4 (each within the scatter of the next). At a limit, above all of these: compound 3.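

Within the data shown here, with hydrogen in place of hydroxy on an aromatic carbon, ortho to a hydroxy group and meta to a large group, this assay records a 1.0-fold higher number from compound 2 to compound 4 (0.00 log units; within the scatter) and this is the first pair that shows this change alone. Among these compounds, at this position the hydroxy of compound 2 can therefore go without any reading beyond the scatter in this test, something the earlier compounds could not show, since compound 1 differs from compound 2 in more than one place. Nothing measured in the series bears on why this step has the size it has.

Whether the remaining hydroxy matters stays open, since no compound shown pairs compound 4 with an analogue that differs only at that hydroxy. Also open, as far as these compounds go, is how a methoxy, an amine or a carboxylic acid would read at the position vacated in compound 4, and whether any of them would separate from compound 2 beyond the scatter.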